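Phenyl for thiophene on a quinolinone gonadotropin antagonist

This account rests on a few compounds, and the source may have more. Where it says the series, first, only, none or still open, it means among the compounds named here.

Compound 3 `O=[N+]([O-])c1cc2c(OCCC3CCCCN3)c(-c3cccs3)c(O)nc2cc1Cl` has the lowest number of the three measured compounds: in a functional assay on cells (Pituitary gland cell) for antagonist activity at Gonadotropin-releasing hormone receptor (Rattus norvegicus) (on this read-out lower numbers stand for stronger inhibition and higher numbers for weaker inhibition), compound 3 gives 220 nM. Compound 2 `Cc1ccc(-c2c(O)nc3cc(Cl)c([N+](=O)[O-])cc3c2OCCC2CCCCN2)c(C)c1` gives 400 nM in this assay, and compound 1 `COc1ccc(-c2c(O)nc3cc(Cl)c([N+](=O)[O-])cc3c2OCCC2CCCCN2)cc1OC` gives 600 nM. For the measured compounds named here, the gap from compound 1 to compound 3 is a 2.7-fold lower number from compound 1 to compound 3 (0.44 log units; beyond the scatter), and from compound 2 to compound 3 it is a 1.8-fold lower number from compound 2 to compound 3 (0.26 log units; within the scatter), so only the step from compound 1 lies beyond the scatter. Compound 4 `O=[N+]([O-])c1cc2c(OCCC3CCCCN3)c(-c3ccccc3)c(O)nc2cc1Cl` differs from compound 3 by phenyl in place of thiophen-2-yl on an aromatic carbon. The two measured aryl-to-thiophene steps were modest or within the scatter, so the return to a plain carbocycle is expected to cost little: for compound 4 in this assay a step of a 1.5-fold higher number from compound 3 to compound 4 (0.16 log units; within the scatter) is expected. Compound 4 is therefore estimated at 320 nM, within 130 nM to 800 nM.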

Compound 4, half-maximal inhibitory concentration: 410 nM
Compound 4: middle estimate off by 1.3-fold (0.11 log units), on the low side; the range from low to high includes it.
By their numbers in this assay, from the lowest: compounds 3, 2, 4 and 1 (each within the scatter of the next, the first and the last beyond it).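

In this assay the plain phenyl of compound 4 gives a reference without substituents, and the thiophen-2-yl (a 1.9-fold higher number from compound 3 to compound 4 (0.27 log units; within the scatter)), the 2,4-dimethylphenyl (a 1.0-fold higher number from compound 2 to compound 4 (0.01 log units; within the scatter)) and the 3,4-dimethoxyphenyl (a 1.5-fold lower number from compound 1 to compound 4 (0.17 log units; within the scatter)) all stay within the scatter of it. Compound 4 thus lies within the scatter of both compound 1 and compound 3, although those two lie beyond the scatter of each other.

As far as these compounds go, whether an amine or a carboxylic acid on the phenyl would move the number further remains open. Nothing given here accounts for the size of these steps.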